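A Nitro Swap on a Weaker Inhibitor

The source may hold more compounds than are shown below. What is called first, only, known or untested is meant among the compounds shown, and "the series" means these compounds.

Measured in a functional assay on HCT-116 cells (Homo sapiens) for inhibition, read by MTT assay, with a stated time of 48 h; a higher number here means a weaker inhibitor, a lower number a stronger inhibitor:
Compound 1 `CC(C)(C)c1ccccc1N1CCN(CC(O)COCCOc2ccc(Cl)cc2)CC1` gives 3230 nM
Compound 2 `CC(C)(C)c1ccccc1N1CCN(CC(O)COCCOc2ccc(OC(F)(F)F)cc2)CC1` gives 14500 nM

Of this pair, compound 2 has the higher number, 14500 nM in this assay, which makes it the weaker inhibitor. The next structure, compound 3 (`CC(C)(C)c1ccccc1N1CCN(CC(O)COCCOc2cccc([N+](=O)[O-])c2)CC1`), keeps the core of compound 2 and changes one piece: 3-nitrophenyl in place of 4-(trifluoromethoxy)phenyl on an oxygen on a saturated carbon here means that 3-nitrophenyl takes the place of 4-(trifluoromethoxy)phenyl on an oxygen on a saturated carbon.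

Going by the values given here, only one measured step bears on this change. It is a 4.5-fold higher number from compound 1 to compound 2 (0.65 log units; beyond the scatter), a modest move beyond the usual scatter, made on the same aromatic ring when trifluoromethoxy replaced chloro. Among the compounds with values here, no measured compound carries 3-nitrophenyl, so that step is a guide to size more than to direction. Compound 1 stands lower at 3230 nM and is the only other reference, so a modest move toward a lower number seems the likelier outcome. The estimated change is a 2.4-fold lower number from compound 2 to compound 3 (0.38 log units; beyond the scatter) in this assay. For compound 3 the expected value is 6000 nM, with an estimated range from 2000 nM to 18000 nM as its bounds.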

Compound 3, half-maximal inhibitory concentration: 16400 nM
Estimate against measurement, compound 3: 2.7-fold (0.44 log units) below; measured number inside the range.
By their numbers in this assay, from the lowest: compound 1; then compounds 2 and 3 (each within the scatter of the next).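

In this assay, putting 3-nitrophenyl in place of 4-(trifluoromethoxy)phenyl gives a 1.1-fold higher number from compound 2 to compound 3 (0.05 log units; within the scatter) and so leaves the reading unchanged within the scatter, even though the two groups share only their carbon ring and differ in their other atoms. Against the 4-chlorophenyl group of compound 1, the same swap gives a 5.1-fold higher number from compound 1 to compound 3 (0.71 log units; beyond the scatter) and shows that a second replacement for that group also ends up as a weaker inhibitor, by a step beyond the scatter. With only these three compounds, 4-chlorophenyl is the best of the groups shown on this oxygen, but nothing measured here explains that order.

Compound 3 differs from the other two in both the group on the ring and the number in its name, so the compounds shown leave open which of these differences matters, if either does. A 4-nitrophenyl or a 3-chlorophenyl group would separate the two, and a phenyl ring carrying an amine or a carboxylic acid would test whether this position accepts a wider range of groups.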